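Heteroaryl replacements on the shared core: outlook for compound 4

A few compounds are considered here, and "the series" means these few. Any claim that something is new, unique, unknown or untested is made for them only; others in the source may bear on it.

Measured so far in an assay on isolated protein for antagonist activity at C-C chemokine receptor type 9 (Homo sapiens); on this read-out lower numbers stand for stronger inhibition and higher numbers for weaker inhibition:
compound 1 `CC(C)(C)c1ccc(S(=O)(=O)Nc2ccc(Cl)cc2-c2nccc(CO)c2O)cc1` gives 330 nM
compound 2 `CC(C)(C)c1ccc(S(=O)(=O)Nc2ccc(Cl)cc2-c2nc(N)ncc2O)cc1` gives 30 nM
compound 3 `CN(C)c1ncnc(-c2cc(Cl)ccc2NS(=O)(=O)c2ccc(C(C)(C)C)cc2)c1O` gives 105 nM

Compound 1 stands highest of the three numbers in this assay; compound 3 is nearest and compound 2 furthest from it. Compound 4 `CC(C)(C)c1ccc(S(=O)(=O)Nc2ccc(Cl)cc2-c2nccnc2NCCO)cc1` differs from compound 1 in one place: a group of 10 heavy atoms (6 carbon, 3 nitrogen, 1 oxygen; one six-membered aromatic ring with 2 hetero atoms) in place of a group of 9 heavy atoms (6 carbon, 1 nitrogen, 2 oxygen; one six-membered aromatic ring with 1 hetero atom), on an aromatic carbon. Among the measured compounds shown here, two measured steps bear on this change, both replacing the same group on the same aromatic carbon of compound 1: an 11-fold lower number from compound 1 to compound 2 (1.04 log units; beyond the scatter) and a 3.1-fold lower number from compound 1 to compound 3 (0.50 log units; beyond the scatter). Both lowered the number beyond the scatter, one large, one modest. The group entering compound 4 is of a size closer to that of compound 3, so a modest lowering is expected rather than the large one. Compound 4 is therefore estimated at 140 nM, with a range from 45 nM to 450 nM. The expected step is a 2.4-fold lower number from compound 1 to compound 4 (0.37 log units; beyond the scatter).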

Compound 4, half-maximal inhibitory concentration: 34 nM
Compound 4: middle estimate off by 4.1-fold (0.61 log units), on the high side; measured number outside the range, below it.
By their numbers in this assay, from the lowest: compounds 2 and 4 (each within the scatter of the next); then compound 3; then compound 1.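

Compounds 3 and 4 bring in groups with the same heavy-atom count, yet a 3.1-fold lower number from compound 3 to compound 4 (0.49 log units; beyond the scatter) shows that this count does not fix the result in this assay. Meanwhile, a 9.7-fold lower number from compound 1 to compound 4 (0.99 log units; beyond the scatter) shows that a group larger than that of compound 1 can still give a lower number at this aromatic carbon, and a 1.1-fold higher number from compound 2 to compound 4 (0.05 log units; within the scatter) puts compound 4 with compound 2 despite its larger group. No measured evidence explains these differences.

Each step replaces the whole group, so the part responsible remains unresolved. Also open, from the compounds shown here alone, is how a carboxylic acid or a longer chain on the entering ring would read out.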